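Amide-nitrogen substituent series: compound 3 to compound 4

The compounds below may be only part of what the source reports. "The series", "measured", "known", "first", "only" and "open" are said of these compounds alone.

Measured compounds:
Compound 1 `CNC(=O)c1ccncc1Nc1cc(-c2ccc3ccn(C)c3c2)c2nccnc2c1`: 83 nM
Compound 2 `Cn1cc(NC(=O)c2ccncc2Nc2cc(-c3ccc4ccn(C)c4c3)c3nccnc3c2)cn1`: 33 nM
Compound 3 `CC(=O)N1CCOC(CNC(=O)c2ccncc2Nc2cc(-c3ccc4ccn(C)c4c3)c3nccnc3c2)C1`: 93 nM

In an assay for inhibition of 6-phosphofructo-2-kinase/fructose-2,6-bisphosphatase 3 (Homo sapiens), read by ADP-Glo, with a stated time of 2 h (on this read-out lower numbers stand for stronger inhibition and higher numbers for weaker inhibition), compound 3 gives the highest of the three numbers; compound 1 sits nearest with a 1.1-fold higher number from compound 1 to compound 3 (0.05 log units; within the scatter), compound 2 furthest with a 2.8-fold higher number from compound 2 to compound 3 (0.45 log units; beyond the scatter). Compound 4 `CC(=O)N1CCC(NC(=O)c2ccncc2Nc2cc(-c3ccc4ccn(C)c4c3)c3nccnc3c2)C1` is not yet measured. It differs from compound 3 by 1-acetylpyrrolidin-3-yl in place of (4-acetylmorpholin-2-yl)methyl on an amide-type nitrogen. Both earlier steps vary the same amide-nitrogen substituent: a 1.1-fold higher number from compound 1 to compound 3 (0.05 log units; within the scatter) lies within the scatter, a 2.5-fold lower number from compound 1 to compound 2 (0.40 log units; beyond the scatter) is modest. Exchanging one acetylated saturated ring for another at this position is therefore expected to move this assay little, with no clear direction beyond the scatter. For compound 4 the expected step is a 1.2-fold lower number from compound 3 to compound 4 (0.07 log units; within the scatter), giving an estimate of 80 nM with a range of 35 nM to 180 nM.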

Compound 4, half-maximal inhibitory concentration: 105 nM
The estimate for compound 4 lay 1.3-fold (0.12 log units) below the measured number; the measured number falls inside the stated range.
By their numbers in this assay, from the lowest: compound 2; then compounds 1, 3 and 4 (each within the scatter of the next).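

In this assay, the six-membered ring with 2 hetero atoms gives way to the five-membered ring with 1 hetero atom with no change beyond the scatter (a 1.1-fold higher number from compound 3 to compound 4 (0.05 log units; within the scatter)), and the same holds against plain methyl (a 1.3-fold higher number from compound 1 to compound 4 (0.10 log units; within the scatter)). Only 1-methyl-1H-pyrazol-4-yl stands apart from the new group (a 3.2-fold higher number from compound 2 to compound 4 (0.50 log units; beyond the scatter)), so neither acetylated saturated ring separates from methyl. Nothing available bears on the cause of this pattern. Open, going by these compounds, is whether a phenyl or pyridine ring on this nitrogen matches 1-methyl-1H-pyrazol-4-yl, and how an amine or carboxylic acid in place of the acetyl group would read.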